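Fluoro for Chloro on a Shared Benzyl Group

A few compounds are considered here, and "the series" means these few. Any claim that something is new, unique, unknown or untested is made for them only; others in the source may bear on it.

Compound 1 `CC1=C(C(=O)Nc2ccc(F)cc2)C(c2ccc([N+](=O)[O-])cc2)N=C(SCc2ccc(Cl)cc2)N1` and compound 2 `CC1=C(C(=O)Nc2ccc(F)cc2)C(c2ccc([N+](=O)[O-])cc2)N=C(SCc2ccc(F)cc2)N1` share one core and differ in a single place: fluoro in place of chloro on an aromatic carbon. In a functional assay on the whole organism (artery, strain albino) with Rattus norvegicus as the target, with a stated time of 120 min, at a dose of 10 mg/kg by the oral route (on this read-out higher numbers stand for more inhibition at the one dose given (going by the name of the read-out) and lower numbers for less inhibition), compound 1 gives 16%, and compound 2 gives 17%; the step of a number 1 percentage points higher from compound 1 to compound 2 (within the scatter) is small. Compound 3 `CC1=C(C(=O)Nc2ccc(Br)cc2)C(c2ccc(Cl)cc2Cl)N=C(SCc2ccc(Cl)cc2)N1` is built on a different core, and the difference between the cores of compound 1 and compound 3 is not broken down here. In this assay compound 3 gives 17.5%, a number close to both earlier ones. Compound 4 `CC1=C(C(=O)Nc2ccc(Br)cc2)C(c2ccc(Cl)cc2Cl)N=C(SCc2ccc(F)cc2)N1` has not yet been measured; it differs from compound 3 in exactly the way compound 2 differs from compound 1, namely (fluoro in place of chloro on an aromatic carbon), at the same place. Because this change once gave a number 1 percentage points higher from compound 1 to compound 2 (within the scatter), a movement no larger than the ordinary spread of repeated measurements, the same change is expected to leave compound 4 close to compound 3. The expected step is a number 0.5 percentage points higher from compound 3 to compound 4 (within the scatter). The estimate for compound 4 in this assay is therefore 18%, with a likely range from 8% to 28%.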

Compound 4, a percentage reported as inhibition, in the whole organism at one dose (the size of the read-out at that dose, not a potency): 22.7%
Compound 4: the middle estimate sits 4.7 percentage points below what was measured; measured number inside the range.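

In this assay, fluoro in place of chloro on the benzyl group gives a number 5.2 percentage points higher from compound 3 to compound 4 (within the scatter), so on this second core the change again leaves the number about where it was. Set side by side, the two steps cannot be told apart, and the change behaves alike on both cores as far as this read-out can show: the same change on two cores in this assay, a number 1 percentage points higher (within the scatter) from compound 1 to compound 2 and a number 5.2 percentage points higher (within the scatter) from compound 3 to compound 4, 4.2 percentage points apart, within the scatter of two such steps This does not prove that fluoro truly raises the number, since each step is small enough to be ordinary scatter, and two pairs of compounds cannot show how the change would behave on a third core.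

The compounds shown carry only chloro or fluoro at this place, so it stays open how an amine, a carboxylic acid or a methoxy group there would read. From the compounds shown here alone, it also stays open whether replacing the whole 4-fluorobenzyl group with a longer chain would move the number by more than the scatter.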